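This account rests on a few compounds, and the source may have more. Where it says the series, first, only, none or still open, it means among the compounds named here.

Of the compounds shown here, three have been tested in a functional assay on the whole organism with Rattus norvegicus as the target, in the maximal electroshock model (a lower number here means that less compound is needed, a higher number that more compound is needed for the effect), and a fourth awaits testing.

Compound 1, `CNc1ncnc2c1cnn2Cc1ccccc1`, gives 7 mg/kg in this assay. Compound 2, `Nc1ncnc2c1cnn2Cc1ccccc1`, differs from compound 1 by hydrogen in place of methyl on a nitrogen on an aromatic ring. For compound 2 this assay returns only a limit, > 25 mg/kg, not a number. The step is therefore an at least 3.5-fold higher number from compound 1 to compound 2 (0.55 log units; beyond the scatter), and the evidence behind it is the limit of > 25 mg/kg in this assay, at which 1 of the 3 values shown sits.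

Compound 3, `CNc1ncnc2c1nnn2Cc1ccccc1F`, gives 3 mg/kg in this assay. Of the two numbers reported, this is the lowest; the nearest is compound 1, whose number is higher by a margin that is beyond the scatter. The difference between the core of compound 3 and the core of compound 1 is not broken down here.

Compound 4, `Nc1ncnc2c1nnn2Cc1ccccc1F`, is not yet measured. It differs from compound 3 by hydrogen in place of methyl on a nitrogen on an aromatic ring. For the measured compounds named here, this is the same change, at a place described in the same words, as the one made from compound 1 to compound 2, so the earlier step is the only guide to its size. Since that step pushed compound 2 to a limit, the same change on compound 3 is expected to raise the number by a similar amount, giving an estimated step of a 5.0-fold higher number from compound 3 to compound 4 (0.70 log units; beyond the scatter). Compound 4 is therefore expected to give about 15 mg/kg in this assay, with a range from 6 mg/kg to 40 mg/kg, and a real chance that only a limit is reported.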

Compound 4, dose for half-maximal effect: > 25 mg/kg
Compound 4: only a limit was reported (the forecaster's own chance of this, stated with the estimate: 40%); middle value at least 1.6-fold (0.22 log units) away from the limit.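

On the second core, putting hydrogen in place of methyl on the nitrogen again moves the number upward, with an at least 8.3-fold higher number from compound 3 to compound 4 (0.92 log units; beyond the scatter). In this assay, the direction of this change therefore carries over between the two cores shown, with the methylamino compound needing less compound than its amino partner each time: the same change on two cores in this assay, an at least 3.5-fold higher number (0.55 log units; beyond the scatter) from compound 1 to compound 2 and an at least 8.3-fold higher number (0.92 log units; beyond the scatter) from compound 3 to compound 4; the limit leaves it open whether they differ This does not show that the size of the change carries over, since compound 2 and compound 4 each give a limit rather than a number, and the true gap on either core could be larger than the step shows: the limit of > 25 mg/kg in this assay, at which 2 of the 4 values shown sit.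

The compounds shown carry only methyl or hydrogen on this nitrogen, which leaves open how a longer chain such as ethyl, or a larger group such as benzyl, would fare in this assay. Going by these compounds, compound 1 and compound 3 also differ in more than one place, so the separate contributions of the core and of the fluorine on the benzyl group remain open as well.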